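The compounds below may be only part of what the source reports. "The series", "measured", "known", "first", "only" and "open" are said of these compounds alone.

The compounds measured so far:
compound 1, `CC(C)CCC(=O)Nc1c(C(O)(C(F)(F)F)C(F)(F)F)ccc2ccccc12`: 49 nM
compound 2, `COCC(=O)Nc1c(C(O)(C(F)(F)F)C(F)(F)F)ccc2ccccc12`: 213 nM
compound 3, `O=C(Nc1ccc(Cl)cc1)Nc1c(C(O)(C(F)(F)F)C(F)(F)F)ccc2ccccc12`: 276 nM

All three were tested in an assay on LtK cells with ATP-sensitive inward rectifier potassium channel 11 (Homo sapiens) as the target; a lower number here means that less compound is needed, a higher number that more compound is needed for the effect. Compound 3 has the highest number of the three. Its nearest neighbour is compound 2, and a 1.3-fold higher number from compound 2 to compound 3 (0.11 log units; within the scatter) lies within the scatter, so these two cannot be told apart. The gap to compound 1 is wider: a 5.6-fold higher number from compound 1 to compound 3 (0.75 log units; beyond the scatter) lies beyond the scatter.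

Compound 4 is `O=C(Nc1c(C(O)(C(F)(F)F)C(F)(F)F)ccc2ccccc12)c1cccc(C(F)(F)F)c1`. Compared with compound 3 the change is 3-(trifluoromethyl)phenyl in place of (4-chlorophenyl)amino on a carbonyl carbon. The group that leaves carried a hydrogen-bond donor; the group that enters carries none.

Among the compounds with values here, two measured steps touch this carbonyl carbon. a 5.6-fold higher number from compound 1 to compound 3 (0.75 log units; beyond the scatter) was modest, and a 1.3-fold higher number from compound 2 to compound 3 (0.11 log units; within the scatter) stayed within the scatter. Within the data shown here, neither step places a ring directly on the carbonyl carbon, so no measured step matches the change to compound 4 closely. The measured variation at this position spans modest steps only, so for compound 4 a modest step in either direction, or none beyond the scatter, is expected. The number for compound 4 in this assay is estimated at 150 nM, with a range from 40 nM to 600 nM. For compound 4 this means an expected 1.8-fold lower number from compound 3 to compound 4 (0.26 log units; within the scatter).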

Compound 4, half-maximal effective concentration: 84 nM
The estimate for compound 4 lay 1.8-fold (0.25 log units) above the measured number; the measured number falls inside the stated range.
By their numbers in this assay, from the lowest: compounds 1 and 4 (each within the scatter of the next); then compounds 2 and 3 (each within the scatter of the next).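

Within the data shown here, compound 4 is the first compound here with an aromatic ring bound directly to the carbonyl carbon, and in this assay this change separates it from the urea compound 3: a 3.3-fold lower number from compound 3 to compound 4 (0.52 log units; beyond the scatter). It also separates it from the methoxymethyl amide, with a 2.5-fold lower number from compound 2 to compound 4 (0.40 log units; beyond the scatter), whereas a 1.7-fold higher number from compound 1 to compound 4 (0.23 log units; within the scatter) means that 3-(trifluoromethyl)phenyl and isopentyl cannot be told apart at this position, so a ring here is compatible with a number as low as the one for the alkyl chain. No measurement is available to explain these differences.

The step from compound 3 to compound 4 removes the amide-type nitrogen of the (4-chlorophenyl)amino group and replaces chlorine with trifluoromethyl at the same time, so the compounds shown cannot assign the change to either part; 4-chlorophenyl on this carbonyl carbon would separate the two. As far as these compounds go, how a cyclohexyl ring or a chain longer than isopentyl would compare at this carbonyl carbon also remains open.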